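Swapping Trifluoromethyl for Chloro on a Shared Core

The compounds below may be only part of what the source reports. "The series", "measured", "known", "first", "only" and "open" are said of these compounds alone.

Compound 1 `O=C(Nc1cccc(-c2ccc(-c3ccccc3)cc2)c1)C(Cl)Cl`: > 50000 nM (a limit of the assay, not a number)
Compound 2 `O=C(Nc1cccc(-c2ccc(C(F)(F)F)cc2)c1)C(Cl)Cl`: 23500 nM

Both compounds were tested in a functional assay on A549 cells (Homo sapiens) for cytotoxicity, read by MTT assay, with a stated time of 68 h; on this read-out lower numbers stand for stronger inhibition and higher numbers for weaker inhibition. For the measured compounds named here, compound 2, at 23500 nM, holds the only true number so far. The result for compound 1 is a limit of the assay.

Compound 3 `O=C(Nc1cccc(-c2ccc(Cl)cc2)c1)C(Cl)Cl` carries chloro in place of trifluoromethyl on an aromatic carbon, para to a large group (chloro in place of trifluoromethyl on an aromatic carbon). Going by the values given here, one measured step concerns this same place: trifluoromethyl in place of phenyl gave an at least 2.1-fold lower number from compound 1 to compound 2 (0.32 log units; beyond the scatter). As far as these compounds go, it starts from a limit, so its true size is unknown, and chloro has not been measured here. Starting from compound 2 at 23500 nM, no step beyond the scatter is therefore expected in this assay. The expected step is a 1.2-fold lower number from compound 2 to compound 3 (0.07 log units; within the scatter). Compound 3 is estimated at 20000 nM, with an expected range of 8000 nM to 50000 nM.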

Compound 3, half-maximal inhibitory concentration: 36200 nM
Compound 3: the middle estimate sits 1.8-fold (0.26 log units) below what was measured, and the stated range covers the measured number.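

In this assay, chloro and trifluoromethyl on an aromatic carbon, para to a large group, cannot be told apart: the swap gives a 1.5-fold higher number from compound 2 to compound 3 (0.19 log units; within the scatter), so one heavy atom here reads the same as four. The comparison with phenyl gives an at least 1.3-fold lower number from compound 1 to compound 3 (0.14 log units; that floor lies within the scatter), and a floor of that size does not separate chloro from phenyl. The true size of that step cannot be read, and the value it starts from is a limit of the assay, not a number: the limit of > 50000 nM in this assay, at which 1 of the 3 values shown sits.

What the compounds shown leave open is how a group of a different kind would read at this place, such as an amine, a carboxylic acid or a methoxy group. They also cannot tell whether the same swap elsewhere on the shared core would read the same way.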